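The source may report more compounds than this note shows. Statements on the series, on what has been measured and on what is new or still open speak of the compounds shown alone.

Measured compounds:
compound 1, `O=C(CN1CCN(C2CCCCC2)CC1)Nc1nc2c(s1)CCCC2`: > 10000 nM
compound 2, `O=C(CN1CCN(c2ccc(F)cc2)CC1)Nc1nc2ccccc2s1`: > 10000 nM
compound 3, `O=C(CN1CCN(c2ccc(F)cc2)CC1)Nc1nc2c(s1)CCC2`: > 10000 nM

In an assay on isolated protein for inhibition of long-chain fatty acid transport protein 1 (Mus musculus), read by scintillation counting, with a stated time of 20 min (a higher number here means a weaker inhibitor, a lower number a stronger inhibitor), compound 1 gives only a limit of the assay and no number, > 10000 nM. Compound 2 likewise gives only a limit in this assay, > 10000 nM. Compound 3 too sits at a limit, > 10000 nM. Compound 1 therefore stands nowhere in particular on the numbers shown: all three values are the same limit, as the limit of > 10000 nM in this assay, at which 3 of the 3 values shown sit, records, and no ordering among the three can be drawn from them.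

The compound yet to be measured is compound 4, `O=C(CN1CCN(c2ccc(F)cn2)CC1)Nc1nc2c(s1)CCCC2`. It differs from compound 1 in one place: 5-fluoropyridin-2-yl in place of cyclohexyl on an amine nitrogen in a ring. The shared core of compound 1 and the piperazine-linked amide are kept; only the group on the ring nitrogen changes. Compounds 2 and 3 carry an aromatic ring on that same nitrogen and both sit at the limit, which offers no sign that an aromatic group there brings measurable inhibition. Going by the values given here, no measured pair in this set differs in exactly one place, so no step can be read from the data. Compound 4 is expected to give 6000 nM, with a range from 1000 nM to 30000 nM. Compound 4 is thus expected to move an at least 1.6-fold lower number from compound 1 to compound 4 (0.22 log units; that floor lies within the scatter) from the limit of compound 1, with a real chance that it too is reported only as a limit.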

Compound 4, half-maximal inhibitory concentration: 600 nM
Compound 4: middle estimate off by 10-fold (1.00 log units), on the high side; the measured number lies below the stated range.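

In this assay, the group on the amine nitrogen in a ring proves able to decide whether inhibition can be read at all: with the shared core and the amide kept, 5-fluoropyridin-2-yl in place of cyclohexyl gives an at least 16-fold lower number from compound 1 to compound 4 (1.22 log units; beyond the scatter). Compound 1 gives only a limit of the assay, > 10000 nM, so this single change is what brings the series from a limit to a true number in this set. Among the compounds shown, a number rather than a limit appears only for compound 4: the limit of > 10000 nM in this assay, at which 3 of the 4 values shown sit.

The compounds shown do not separate the parts of the entering group, so the ring nitrogen, the fluorine and the aromatic ring itself cannot be told apart as the source of the step, and an unsubstituted pyridin-2-yl or a chlorine or methoxy group in place of the fluorine on the same core would be needed to do so. They also leave open whether the step carries over to other cores, since no pair shown varies the core while keeping 5-fluoropyridin-2-yl on the ring nitrogen.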